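This account rests on a few compounds, and the source may have more. Where it says the series, first, only, none or still open, it means among the compounds named here.

Compounds measured so far:

- compound 1, `COc1cc(/C=C2\CCC/C(=C\c3ccccc3[N+](=O)[O-])C2=O)cc(OC)c1OC`: 702 nM
- compound 2, `O=C1/C(=C/c2ccc(F)cc2)CCC/C1=C\c1ccc([N+](=O)[O-])cc1`: 17100 nM
- compound 3, `COc1ccc(/C=C2\CCC/C(=C\c3cccc([N+](=O)[O-])c3)C2=O)cc1`: 7980 nM

All three were tested in a functional assay on MOLT-4 cells (Homo sapiens) for cytotoxicity, with a stated time of 72 h; a lower number here means a stronger inhibitor, a higher number a weaker inhibitor. Compound 1 gives 702 nM, compound 3 gives 7980 nM, and compound 2 gives 17100 nM. Compound 2 thus stands at the highest number of the three, which means it is the weakest inhibitor here; its gap to compound 3 is beyond the scatter, and its gap to compound 1 is far beyond it.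

Within the data shown here, the unmeasured compound 4, `CN(C)c1ccc(/C=C2\CCC/C(=C\c3ccc([N+](=O)[O-])cc3)C2=O)cc1`, keeps the shared core of compound 2 and changes only one group: dimethylamino in place of fluoro on an aromatic carbon. Among the measured compounds shown here, since no step between measured compounds is given for this kind of change, the expectation has to rest on the position of compound 2 alone. Because compound 2 sits at 17100 nM, the highest number in the set, the step is expected to move downward by a moderate amount, a 4.9-fold lower number from compound 2 to compound 4 (0.69 log units; beyond the scatter), rather than upward. Compound 4 is therefore estimated at 3500 nM, with a range from 800 nM to 13000 nM.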

Compound 4, half-maximal inhibitory concentration: > 500000 nM
Compound 4 was reported as a limit; the forecaster's own chance of this, stated with the estimate: 5%; middle value at least 140-fold (2.15 log units) from the limit.
By their numbers in this assay, from the lowest: compound 1; then compound 3; then compound 2. At a limit, above all of these: compound 4.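

Compound 2's fluoro position tolerates change poorly: with the rest of the molecule unchanged, placing dimethylamino there in this assay gives an at least 29-fold higher number from compound 2 to compound 4 (1.46 log units; beyond the scatter). The earlier compounds shown here differ from one another in more than one place, so they could not show what this single position does; this step isolates it, and the change makes the compound a much weaker inhibitor. On these data alone, compound 4 is reported only as a limit, so the true size of the step stays unknown: the limit of > 500000 nM in this assay, at which 1 of the 4 values shown sits.

As far as these compounds go, it remains open whether a smaller nitrogen group, such as a plain amine, or a different kind of group, such as a carboxylic acid, would be tolerated at this place on the ring. From the compounds shown here alone, it also remains open whether the same exchange would have a similar effect on a compound whose other aromatic ring is substituted differently.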